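Chloro to Azido Where Cytotoxicity Readings Have Not Moved

A few compounds are considered here, and "the series" means these few. Any claim that something is new, unique, unknown or untested is made for them only; others in the source may bear on it.

In a functional assay on HFF cells (Homo sapiens) for cytotoxicity (a higher number here means a weaker inhibitor, a lower number a stronger inhibitor), three compounds have been measured so far, and their readings coincide. Compound 1 `CC(=O)OC1C(CCl)OC(n2c(Cl)nc3cc(Cl)c(Cl)cc32)C1OC(C)=O` gives 32000 nM. Compound 2 `CSCC1OC(n2c(Cl)nc3cc(Cl)c(Cl)cc32)C(OC(C)=O)C1OC(C)=O` gives 32000 nM. Compound 3 `CC1(C)OC2C(CCl)OC(n3c(Cl)nc4cc(Cl)c(Cl)cc43)C2O1` gives 32000 nM, which places it level with the other two.

The next compound to be tested is compound 4 `CC1(C)OC2C(CN=[N+]=[N-])OC(n3c(Cl)nc4cc(Cl)c(Cl)cc43)C2O1`. It keeps the structure of compound 3 except for one change: azido in place of chloro on a saturated chain carbon bound to a saturated ring carbon.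

For the measured compounds named here, one measured step bears directly on this change, since it also replaces chloro at that kind of carbon, there with methylsulfanyl. That step, no change at the digits printed from compound 1 to compound 2 (within the scatter), lies within the scatter. Going by the values given here, it is only a single example, however, and no measured compound carries an azido group, so the data offer no direct evidence on azido itself.

Among the compounds with values here, with only that one step as a guide, no shift in either direction can be predicted in this assay. The expected change is no change at the digits printed from compound 3 to compound 4 (within the scatter), which means no step beyond the scatter. The estimated value for compound 4 is 32000 nM, with an expected range from 14000 nM to 70000 nM.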

Compound 4, half-maximal inhibitory concentration: 32000 nM
Compound 4: middle estimate and measured number agree at the digits printed; the measured number falls inside the stated range.
By their numbers in this assay, from the lowest: compounds 1, 2, 3 and 4 (each within the scatter of the next).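

For the compounds shown here, with azido in place of chloro on a saturated chain carbon bound to a saturated ring carbon, the reading shows no change at the digits printed from compound 3 to compound 4 (within the scatter) in this assay, the first reading here for a compound carrying an azido group. The earlier compounds shown here showed only that methylsulfanyl could replace chloro at this kind of carbon without moving the reading, and only on the core of compound 1, so the result adds a second replacing group and a second core, that of compound 3. No measurement shown here explains why the reading stays in place for either replacement.

Going by these compounds alone, what the compounds leave open is how far this flat picture extends, since only two replacing groups have been seen at this carbon, each on a single core, and azido has not been seen on the core of compound 1. An amine, a hydroxyl or a longer chain such as ethylsulfanyl in the same place could still give a reading that stands apart from these four.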